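Swapping the urea aryl group in a thienopyrimidine series

The source may hold more compounds than are shown below. What is called first, only, known or untested is meant among the compounds shown, and "the series" means these compounds.

Two urea-bearing compounds have been measured so far. Compound 1, `Cc1ccc(NC(=O)Nc2ccc(-c3nc(NCCCN(C)C)c4sc(Cl)c(Cl)c4n3)cc2)cc1`, gives 1110 nM in a functional assay on NCI-H460 cells (Homo sapiens) for cytotoxicity, read by MTT assay, with a stated time of 72 h; a higher number here means a weaker inhibitor, a lower number a stronger inhibitor. Compound 2, `CCN(CC)CCNc1nc(-c2ccc(NC(=O)Nc3ccccc3Cl)cc2)nc2c(Cl)c(Cl)sc12`, gives 460 nM in this assay, the lowest of the two numbers, with compound 1 standing at a higher number beyond the usual scatter. The next compound, compound 3, `CCN(CC)CCNc1nc(-c2ccc(NC(=O)Nc3ccc(C)cc3)cc2)nc2c(Cl)c(Cl)sc12`, keeps the amine side chain of compound 2 and changes only the aryl group on the urea: 4-methylphenyl in place of 2-chlorophenyl on an amide-type nitrogen. Among the measured compounds shown here, the same 4-methylphenyl group is already present in compound 1, but compound 1 also carries a different amine side chain, so no clean step isolates the effect of the aryl swap. The expectation is a modest move toward a higher number, that is a somewhat weaker inhibitor, with compound 3 estimated at 800 nM, in a range from 350 nM to 2000 nM, corresponding to a 1.7-fold higher number from compound 2 to compound 3 (0.24 log units; within the scatter).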

Compound 3, half-maximal inhibitory concentration: 840 nM
Estimate against measurement, compound 3: 1.1-fold (0.02 log units) below; the range from low to high includes it.
By their numbers in this assay, from the lowest: compounds 2, 3 and 1 (each within the scatter of the next, the first and the last beyond it).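

In this assay, the first clean test of the urea aryl group gives a 1.8-fold higher number from compound 2 to compound 3 (0.26 log units; within the scatter) as its result, so 4-methylphenyl and 2-chlorophenyl on this amide-type nitrogen cannot be told apart. The first clean test of the amine side chain gives a 1.3-fold lower number from compound 1 to compound 3 (0.12 log units; within the scatter) as its result, so diethylamino in place of (dimethylamino)methyl also stays within the ordinary spread of repeated measurements. No measured evidence bears on either step, so nothing can be said about what lies behind these numbers.

Still open, from the compounds shown here alone, is whether a different group on the urea, such as an unsubstituted phenyl or a pyridine ring, would move the number beyond the scatter. The same question applies to the side chain, where a morpholine or a carboxylic acid at the chain end could be compared.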